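Swapping 4-cyanophenyl for 3,4-difluorophenyl

The source may hold more compounds than are shown below. What is called first, only, known or untested is meant among the compounds shown, and "the series" means these compounds.

Three compounds have been measured in an ADME assay on microsomes from liver (Mus musculus) for metabolic stability, read by LC-MS, using NADPH, with stated times of 10 min and 30 min, tested at 1 uM (a higher number here means faster removal of the compound, a lower number slower removal), so far:
compound 1 `COC(=O)C1=C(C)NC(c2nccs2)=NC1(C)c1ccc(Cl)cc1` gives 85 mL/min/kg
compound 2 `COC(=O)C1=C(C)NC(c2nccs2)=NC1(C)c1ccc(S(C)(=O)=O)cc1` gives 57 mL/min/kg
compound 3 `COC(=O)C1=C(C)NC(c2nccs2)=NC1(C)c1ccc(C#N)cc1` gives 75 mL/min/kg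

Compound 3, at 75 mL/min/kg, sits within the scatter of the other two (a 1.1-fold lower number from compound 1 to compound 3 (0.05 log units; within the scatter)) and (a 1.3-fold higher number from compound 2 to compound 3 (0.12 log units; within the scatter)). Compound 4 `COC(=O)C1=C(C)NC(c2nccs2)=NC1(C)c1ccc(F)c(F)c1` has 3,4-difluorophenyl in place of 4-cyanophenyl on a saturated ring carbon. The nearest evidence is the set of swaps on the same aromatic ring, which also includes methylsulfonyl in place of chloro (a 1.5-fold lower number from compound 1 to compound 2 (0.17 log units; within the scatter)). Going by the values given here, all of these steps stayed within the scatter, although no measured compound carries fluorine. No step beyond the scatter is therefore expected in this assay here. The expected change is small (a 1.0-fold higher number from compound 3 to compound 4 (0.02 log units; within the scatter)). The estimate for compound 4 is 78 mL/min/kg (expected range 50 mL/min/kg to 115 mL/min/kg).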

Compound 4, clearance: 83 mL/min/kg
For compound 4 the middle estimate is 1.1-fold (0.03 log units) below the measured one, and the stated range covers the measured number.
By their numbers in this assay, from the lowest: compounds 2, 3, 4 and 1 (each within the scatter of the next).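

In this assay, the first fluorine-bearing ring at this saturated ring carbon stays within the scatter of both the nitrile-bearing ring (a 1.1-fold higher number from compound 3 to compound 4 (0.04 log units; within the scatter)) and the chlorine-bearing ring (a 1.0-fold lower number from compound 1 to compound 4 (0.01 log units; within the scatter)). Replacing the whole 4-substituted ring with 3,4-difluorophenyl, which has two ring substituents rather than one, therefore gives no step beyond the scatter. No other measurement here bears on this result. Still open, going by these compounds, is whether an amine or a carboxylic acid on this ring would give a step beyond the scatter.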